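Replacing the ring on compound 2 with 4-hydroxyphenyl

The compounds below may be only part of what the source reports. "The series", "measured", "known", "first", "only" and "open" are said of these compounds alone.

In an ADME assay on the whole organism (Mus musculus, strain Swiss Webster) for pharmacokinetics, read by LC-MS, at a dose of 50 mg/kg by the oral route (on this read-out lower numbers stand for lower exposure and higher numbers for higher exposure at the dose given), compound 1 `O=C(Nc1ccc(F)c(-c2nc3ncc(-c4ccc(F)cc4)cc3[nH]2)c1)N1CCCC1` gives 6270 nM, while compound 2 `O=C(Nc1ccc(F)c(-c2nc3ncc(-c4cccnc4F)cc3[nH]2)c1)N1CCCC1` gives 25600 nM, the higher of the two numbers. For the measured compounds named here, the only measured step is a 4.1-fold higher number from compound 1 to compound 2 (0.61 log units; beyond the scatter). Compound 3 `O=C(Nc1ccc(F)c(-c2nc3ncc(-c4ccc(O)cc4)cc3[nH]2)c1)N1CCCC1` has 4-hydroxyphenyl in place of 2-fluoropyridin-3-yl on an aromatic carbon of compound 2: 4-hydroxyphenyl in place of 2-fluoropyridin-3-yl on an aromatic carbon. Going by the values given here, its new ring is carbon-only, as in compound 1 at 6270 nM, so a fall of similar size is expected, although no measured compound yet carries this hydroxyl group. The expected change is a 5.1-fold lower number from compound 2 to compound 3 (0.71 log units; beyond the scatter). Compound 3 is estimated at 5000 nM, within a range of 1200 nM to 18000 nM.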

Compound 3, maximal plasma concentration: 130 nM
The estimate for compound 3 lay 38-fold (1.59 log units) above the measured number; measured number outside the range, below it.
By their numbers in this assay, from the lowest: compound 3; then compound 1; then compound 2.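

In this assay, the group on this ring position can change the number greatly: moving to 4-hydroxyphenyl gives a 200-fold lower number from compound 2 to compound 3 (2.29 log units; beyond the scatter). Exchanging only fluoro for hydroxy on the carbon-only ring gives a 48-fold lower number from compound 1 to compound 3 (1.68 log units; beyond the scatter), so a carbon-only ring does not by itself set the number, and one substituent on it can matter greatly. Nothing available explains why the hydroxy compound gives so low a number. As far as these compounds go, whether a methoxy or an amino group in place of the hydroxy would give a similarly low number remains open.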